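Tellurium for sulfur, then a cinnamoyl group in place of benzoyl

The source may report more compounds than this note shows. Statements on the series, on what has been measured and on what is new or still open speak of the compounds shown alone.

Measured compounds:
compound 1 `COc1ccc(N(CC(=O)NCCCSc2ccccc2)C(=O)/C=C/c2ccccc2)cc1` — >= 100000 nM
compound 2 `COc1ccc(N(CC(=O)NCCCSc2ccccc2)C(=O)c2ccccc2)cc1` — >= 100000 nM
compound 3 `COc1ccc(N(CC(=O)NCCC[Te]c2ccccc2)C(=O)c2ccccc2)cc1` — 7500 nM

In an ADME assay on cells (Fibroblast, Homo sapiens) for cytotoxicity, read by MTT assay, with a stated time of 24 h (on this read-out lower numbers stand for stronger inhibition and higher numbers for weaker inhibition), compound 1 gives a value that is a limit of the assay, >= 100000 nM. Compound 2 likewise gives only a limit, >= 100000 nM. Among the compounds with values here, compound 3 gives the one real number, 7500 nM. The change a group of 7 heavy atoms (6 carbon, 1 tellurium; one six-membered aromatic ring of carbon only) in place of a group of 7 heavy atoms (6 carbon, 1 sulfur; one six-membered aromatic ring of carbon only), on a saturated chain carbon, three bonds along the chain from an amide-type nitrogen produced an at least 13-fold lower number from compound 2 to compound 3 (1.12 log units; beyond the scatter). The change 2-phenylethenyl in place of phenyl on a carbonyl carbon produced a step that the two limits leave unreadable from compound 2 to compound 1, which cannot be read because both values sit at the limit of >= 100000 nM in this assay, at which 2 of the 3 values shown sit.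

Compound 4 `COc1ccc(N(CC(=O)NCCC[Te]c2ccccc2)C(=O)/C=C/c2ccccc2)cc1` is not yet measured. It differs from compound 3 by 2-phenylethenyl in place of phenyl on a carbonyl carbon, the same change as from compound 2 to compound 1, made on the tellurium-bearing core instead. Since that earlier step gave no readable size, the expected step is no change at the digits printed from compound 3 to compound 4 (within the scatter), an estimate of little change, with compound 4 expected at 7500 nM (range 2500 nM to 25000 nM).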

Compound 4, half-maximal inhibitory concentration: 5000 nM
Compound 4: middle estimate off by 1.5-fold (0.18 log units), on the high side; measured number inside the range.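

In this assay, 2-phenylethenyl in place of phenyl on the carbonyl carbon of the tellurium compounds gives a 1.5-fold lower number from compound 3 to compound 4 (0.18 log units; within the scatter), so this change has no readable effect there. The same change from compound 2 to compound 1 cannot be read, as both values are limits of the assay, so nothing shows that the result holds with sulfur: the limit of >= 100000 nM in this assay, at which 2 of the 4 values shown sit. Tellurium in place of sulfur gives an at least 20-fold lower number from compound 1 to compound 4 (1.30 log units; beyond the scatter), and a large step appears with both carbonyl groups, though its exact size stays unknown: the same change on two cores in this assay, an at least 13-fold lower number (1.12 log units; beyond the scatter) from compound 2 to compound 3 and an at least 20-fold lower number (1.30 log units; beyond the scatter) from compound 1 to compound 4; the limit leaves it open whether they differ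

The compounds shown leave open how selenium would compare with sulfur and tellurium in the same place. They also leave open whether a longer chain carrying the tellurium would shift the number.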